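A Methoxy on the Phenoxy Ring: Expected Permeability

A few compounds are considered here, and "the series" means these few. Any claim that something is new, unique, unknown or untested is made for them only; others in the source may bear on it.

Compound 1, `COc1cccc(CNCCCNc2ccnc3cc(Oc4ccccc4)ccc23)c1O`, gives 317 10^-6 cm/s in an ADME assay for permeability, using PAMPA, with a stated time of 30 min, at pH 7.4; on this read-out lower numbers stand for lower permeability and higher numbers for higher permeability. Compound 2, `c1ccc(Oc2ccc3c(NCCCNCc4ccco4)ccnc3c2)cc1`, gives 317 10^-6 cm/s in this assay, and compound 3, `COc1ccc(F)cc1CNCCCNc1ccnc2cc(Oc3ccccc3)ccc12`, gives 317 10^-6 cm/s. Compound 1 thus stands level with both: no change at the digits printed from compound 1 to compound 2 (within the scatter), no change at the digits printed from compound 1 to compound 3 (within the scatter), and likewise no change at the digits printed from compound 2 to compound 3 (within the scatter). Compound 4, `COc1ccccc1Oc1ccc2c(NCCCNCc3cccc(OC)c3O)ccnc2c1`, differs from compound 1 by methoxy in place of hydrogen on an aromatic carbon. For the measured compounds named here, none of the measured steps touches this part of the shared core; all three exchange the group on the saturated chain carbon bound to the amine nitrogen, and none of them moved the read-out beyond the scatter. Going by the values given here, no step here bears directly on the change made in compound 4. Compound 4 is therefore expected to show no change at the digits printed from compound 1 to compound 4 (within the scatter). Compound 4 is estimated at 317 10^-6 cm/s, with a range of 160 10^-6 cm/s to 630 10^-6 cm/s.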

Compound 4, apparent permeability: 317 10^-6 cm/s
Estimate against measurement, compound 4: no gap at the digits printed; low and high end bracket the measured number.
By their numbers in this assay, from the lowest: compounds 1, 2, 3 and 4 (each within the scatter of the next).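

In this assay the change of phenoxy to 2-methoxyphenoxy gives no change at the digits printed from compound 1 to compound 4 (within the scatter) at this place. This is the only step shown on this ring, as the earlier steps all exchanged the group on the saturated chain carbon, and it extends the flat read-out to a change on an aromatic carbon ortho to a large group. Nothing measured here accounts for this result.

The compounds shown leave open whether an amine or a carboxylic acid in place of the methoxy would also leave the read-out level. They also leave open whether a longer chain on that oxygen would do so.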